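The source may hold more compounds than are shown below. What is called first, only, known or untested is meant among the compounds shown, and "the series" means these compounds.

Measured so far:

- compound 1, `CC(=O)N1CC2CC(C1)N2` — in an assay on SH-EP1 cells for agonist activity at Neuronal acetylcholine receptor; alpha4/beta2 (Homo sapiens), read by FLIPR and calcium flux (on this read-out higher numbers stand for an effect only at larger amounts of compound and lower numbers for an effect already at smaller amounts), compound 1 gives 5100 nM
- compound 2, `O=C([C@H]1C[C@H]1F)N1CC2CC(C1)N2` — in this assay compound 2 gives 210 nM

Among the compounds with values here, compound 2 holds the lowest of the two numbers; its only neighbour is compound 1, and the single measured step, a 24-fold lower number from compound 1 to compound 2 (1.39 log units; beyond the scatter), is large and well beyond the scatter. That step changed the group on the carbonyl carbon, not the arrangement in space.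

Compound 3, `O=C([C@H]1C[C@@H]1F)N1CC2CC(C1)N2`, is still to be measured in this assay. It differs from compound 2 as follows: the two compounds have the same atoms and bonds; at least one stereo element is drawn with a configuration in one of them and without one in the other: 1 of 4 stereo elements differ; a stereocentre at a saturated ring carbon is drawn R in compound 2 and S in compound 3. Within the data shown here, no measured step bears directly on this kind of change: the only step in hand, a 24-fold lower number from compound 1 to compound 2 (1.39 log units; beyond the scatter), swapped a whole group and says nothing about how the two configurations at the saturated ring carbon compare. The one thing the data support is that a 2-fluorocyclopropyl amide, in either configuration, is unlikely to fall back to the number of compound 1; whether compound 3 lands with compound 2 or some way off is open.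

Compound 3 is therefore expected to sit near compound 2 or somewhat weaker, as a 2.4-fold higher number from compound 2 to compound 3 (0.38 log units; beyond the scatter), with the wide range reflecting the absence of any stereochemical comparison in the series.

The estimate for compound 3 is 500 nM, expected to fall between 120 nM and 2500 nM.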

Compound 3, half-maximal effective concentration: 850 nM
The estimate for compound 3 lay 1.7-fold (0.23 log units) below the measured number; the range from low to high includes it.
By their numbers in this assay, from the lowest: compound 2; then compound 3; then compound 1.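

In this assay, the configuration at the saturated ring carbon alone moves the number, with atoms and bonds unchanged: a 4.0-fold higher number from compound 2 to compound 3 (0.61 log units; beyond the scatter) is modest but beyond the scatter, which the earlier group swap could not show. The 2-fluorocyclopropyl in place of methyl on a carbonyl carbon still lowers the number with the S centre, a 6.0-fold lower number from compound 1 to compound 3 (0.78 log units; beyond the scatter), but this gain is smaller than a 24-fold lower number from compound 1 to compound 2 (1.39 log units; beyond the scatter), so its size depends on the configuration at this one ring carbon. The step therefore reads as a difference between stereo drawings rather than a full comparison of two defined isomers, with one limit on that reading: the fact that one of compounds 2 and 3 is drawn with a defined configuration and the other without, at the place where they differ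

A plain cyclopropyl or an ethyl on the carbonyl carbon would show how much of the gain over methyl belongs to the ring and how much to the fluorine. As far as these compounds go, how the remaining configurations of the 2-fluorocyclopropyl amide compare, and whether the preference for the R centre holds with a chlorine in place of the fluorine, stay open.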